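Replacing 1,3-thiazol-2-yl in compound 2

This account rests on a few compounds, and the source may have more. Where it says the series, first, only, none or still open, it means among the compounds named here.

Of the compounds shown here, three that share one core have been measured in a functional assay on SMMC-7721 cells (Homo sapiens) for inhibition, read by MTT assay, with a stated time of 48 h; on this read-out lower numbers stand for stronger inhibition and higher numbers for weaker inhibition. Compound 1 `Cc1ccc(NC(=O)Nc2cccc(-c3cccc4[nH]nc(N)c34)c2)cc1` gives 4450 nM, compound 3 `COc1cccc(NC(=O)Nc2cccc(-c3cccc4[nH]nc(N)c34)c2)c1` gives 2860 nM, and compound 2 `Nc1n[nH]c2cccc(-c3cccc(NC(=O)Nc4nccs4)c3)c12` gives 550 nM. Compound 2 therefore has the lowest number of the three and is the strongest inhibitor in this small set, with both of its gaps beyond the scatter.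

The next compound is compound 4 `Nc1n[nH]c2cccc(-c3cccc(NC(=O)Nc4cccc(C(F)(F)F)c4)c3)c12`, which changes compound 2 in one place: 3-(trifluoromethyl)phenyl in place of 1,3-thiazol-2-yl on an amide-type nitrogen. In words, 3-(trifluoromethyl)phenyl takes the place of 1,3-thiazol-2-yl on an amide-type nitrogen.

Two measured steps make the same kind of exchange between the thiazolyl group and a phenyl group carrying one substituent. The first is a 5.2-fold higher number from compound 2 to compound 3 (0.72 log units; beyond the scatter), and the second, running the opposite way, is an 8.1-fold lower number from compound 1 to compound 2 (0.91 log units; beyond the scatter). The two phenyl compounds themselves stay close, with a 1.6-fold lower number from compound 1 to compound 3 (0.19 log units; within the scatter). Neither carries the trifluoromethyl group, so the guide is indirect. A modest rise in this assay is therefore expected, and the estimate is a 3.6-fold higher number from compound 2 to compound 4 (0.56 log units; beyond the scatter). For compound 4 the estimated value is 2000 nM, with an expected range from 700 nM to 5500 nM.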

Compound 4, half-maximal inhibitory concentration: 1410 nM
The estimate for compound 4 lay 1.4-fold (0.15 log units) above the measured number; the measured number falls inside the stated range.
By their numbers in this assay, from the lowest: compound 2; then compound 4; then compounds 3 and 1 (each within the scatter of the next).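

On this assay the exchange gives a 2.6-fold higher number from compound 2 to compound 4 (0.41 log units; beyond the scatter) and so shows that 1,3-thiazol-2-yl keeps its lead at this amide-type nitrogen over a third substituted phenyl group, as all three phenyl compounds now stand above compound 2. What the phenyl ring carries also turns out to matter, which compounds 1 and 3 alone could not show, since those two lie within the scatter of each other: a 2.0-fold lower number from compound 3 to compound 4 (0.31 log units; beyond the scatter) and a 3.2-fold lower number from compound 1 to compound 4 (0.50 log units; beyond the scatter) are both beyond the scatter, which puts 3-(trifluoromethyl)phenyl lowest among the phenyl groups shown. No measurement shown here explains why these groups differ in this way.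

The compounds shown leave open how a plain phenyl group, or a phenyl group carrying a nitrile, an amine or a carboxylic acid, would compare with compound 4 and with compound 2. They also leave open whether a five-membered aromatic ring other than 1,3-thiazol-2-yl, such as an oxazole or a pyrazole, could match or pass compound 2 at this nitrogen.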